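The source may report more compounds than this note shows. Statements on the series, on what has been measured and on what is new or still open speak of the compounds shown alone.

Measured compounds:
Compound 1 `COc1cccc(N2C(=O)CS/C2=N\c2csc(-c3ccccc3)c2)c1` gives 38300 nM in a functional assay on HT-29 cells (Homo sapiens) for cytotoxicity, read by MTT assay, with a stated time of 72 h; a lower number here means a stronger inhibitor, a higher number a weaker inhibitor.
Compound 2 `COc1cccc(N2C(=O)CS/C2=N\c2csc(-c3ccc(Cl)cc3)c2)c1` gives 24600 nM in this assay.
Compound 3 `O=C1CS/C(=N\c2csc(-c3ccc(Cl)cc3)c2)N1c1ccc(Cl)cc1` gives 36600 nM in this assay.

All three numbers lie within the usual scatter of one another, so no order among them is claimed. The step of a 1.6-fold higher number from compound 2 to compound 1 (0.19 log units; within the scatter) belongs to the change (hydrogen in place of chloro on an aromatic carbon). The step of a 1.5-fold higher number from compound 2 to compound 3 (0.17 log units; within the scatter) belongs to the change of the core, (4-chlorophenyl in place of 3-methoxyphenyl on an amide-type nitrogen in a ring).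

Compound 4 `O=C1CS/C(=N\c2csc(-c3ccc(Cl)cc3)c2)N1c1ccccc1` is not yet measured in this assay. It differs from compound 3 by hydrogen in place of chloro on an aromatic carbon. This is the same change that leads from compound 2 to compound 1, at a place described in the same words, though here on the core of compound 3 rather than that of compound 2. Because a 1.6-fold higher number from compound 2 to compound 1 (0.19 log units; within the scatter) stayed within the scatter, the step from compound 3 to compound 4 is expected to be of similar size, a 1.5-fold higher number from compound 3 to compound 4 (0.18 log units; within the scatter), and compound 4 is expected at about 55000 nM, with a range from 30000 nM to 110000 nM. Going by the values given here, only one earlier instance of the change is available, so this expectation rests on a single step.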

Compound 4, half-maximal inhibitory concentration: 41400 nM
Compound 4: middle estimate off by 1.3-fold (0.12 log units), on the high side; the measured number falls inside the stated range.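

Removing the chloro has now been seen on two cores in this assay, and the two steps agree: the same change on two cores in this assay, a 1.6-fold higher number (0.19 log units; within the scatter) from compound 2 to compound 1 and a 1.1-fold higher number (0.05 log units; within the scatter) from compound 3 to compound 4, 1.4-fold (0.14 log units) apart, within the scatter of two such steps. The new step, a 1.1-fold higher number from compound 3 to compound 4 (0.05 log units; within the scatter), stays within the scatter, as does a 1.7-fold higher number from compound 2 to compound 4 (0.23 log units; within the scatter), which belongs to the exchange of the methoxy for hydrogen, so in these compounds neither exchange produces a step beyond the scatter. Going by these compounds alone, this shows only that the change stays without a measurable effect on both cores; it does not show that an effect of the change carries over from one core to the other, since neither step is large enough to be told from the scatter, and two cores do not establish a rule for the series.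

The aromatic substituents shown are limited to chloro, methoxy and hydrogen. Going by these compounds, it remains open whether an amine, a carboxylic acid or a longer chain in place of the chloro would move the number beyond the scatter, and whether such a step would then hold on both cores.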